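A few compounds are considered here, and "the series" means these few. Any claim that something is new, unique, unknown or untested is made for them only; others in the source may bear on it.

Compound 1 `O=C(Oc1cccc(Br)c1)c1cc2cc([N+](=O)[O-])ccc2oc1=O` gives 35.2% in a functional assay on HT-1080 cells (Homo sapiens), read by transwell migration, with a stated time of 24 h, tested at 1 uM (on this read-out higher numbers stand for a weaker effect at the one concentration tested and lower numbers for a stronger effect), and compound 2 `NCc1ccc2oc(=O)c(C(=O)Oc3cccc(Br)c3)cc2c1` gives 79.3% in this assay. Compound 2 thus stands highest of the two numbers. The step of a number 44.1 percentage points higher from compound 1 to compound 2 (beyond the scatter) is the only measured one, a large one, and it alters the nitro group rather than the amine nitrogen. Compound 3 `CC(=O)NCc1ccc2oc(=O)c(C(=O)Oc3cccc(Br)c3)cc2c1` differs from compound 2 by acetyl in place of hydrogen on an amine nitrogen. Among the compounds with values here, no measured step covers acylation of this amine, so the direction is unanchored. Compound 3 is expected to give 65% in this assay, within 40% to 90%. The expected step is a number 14.3 percentage points lower from compound 2 to compound 3 (beyond the scatter).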

Compound 3, a percentage reported as activity, at one concentration (the size of the read-out at that concentration, not a potency): 36.9%
Estimate against measurement, compound 3: 28.1 percentage points above; measured number below the stated range.
By their numbers in this assay, from the lowest: compounds 1 and 3 (each within the scatter of the next); then compound 2.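

In this assay, acetyl in place of hydrogen on the amine nitrogen gives a number 42.4 percentage points lower from compound 2 to compound 3 (beyond the scatter), so the weak effect of aminomethyl does not carry over to acetamidomethyl. Acetamidomethyl in place of nitro gives a number 1.7 percentage points higher from compound 1 to compound 3 (within the scatter), so on this aromatic carbon the two groups cannot be told apart, and among these three compounds only the free aminomethyl stands apart. No evidence on the reason for this is available.

Open, going by these compounds, is whether a longer acyl chain, a methanesulfonamide or a carboxylic acid at this place would stay level with compound 1 and compound 3.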